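A few compounds are considered here, and "the series" means these few. Any claim that something is new, unique, unknown or untested is made for them only; others in the source may bear on it.

Measured compounds: compound 1 `Cc1cc(N2CC[C@@H](C)[C@@H](N(C)c3ncnc4[nH]ccc34)C2)n2nc(SCc3ccc(C(F)(F)F)cc3)nc2n1` gives 2680 nM in a functional assay on MGC-803 cells (Homo sapiens) for inhibition, read by MTT assay, with a stated time of 72 h; on this read-out higher numbers stand for weaker inhibition and lower numbers for stronger inhibition; compound 2 `C[C@@H]1CCN(c2cc(-c3ccccc3)nc3ncnn23)C[C@@H]1N(C)c1ncnc2[nH]ccc12` gives 84900 nM; compound 3 `CCc1cc(N2CC[C@@H](C)[C@@H](N(C)c3ncnc4[nH]ccc34)C2)n2ncnc2n1` gives 80200 nM.

Compound 1 holds the lowest number of the three measured compounds, with compound 3 some way above it and compound 2 a little further still. Among the compounds with values here, compounds 2 and 3 differ from each other by a 1.1-fold lower number from compound 2 to compound 3 (0.02 log units; within the scatter), the only single-point step among the measured compounds.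

Compound 4 `C=CCSc1nc2nc(C)cc(N3CC[C@@H](C)[C@@H](N(C)c4ncnc5[nH]ccc45)C3)n2n1` is derived from compound 1 by the change (vinyl in place of 4-(trifluoromethyl)phenyl on a saturated chain carbon bound to a sulfur). Within the data shown here, no measured step touches this position; the one step that is known, from compound 2 to compound 3, concerns an aromatic carbon and lies within the scatter, so it gives no direct guidance. Among the measured compounds shown here, what the data do show is that compound 1, the only compound carrying a sulfanyl arm, sits far below compounds 2 and 3, which lack it. Trimming that arm from 4-(trifluoromethyl)benzyl to allyl is therefore expected to move the number upward, though less than the full gap to compound 3. Compound 4 is estimated at 12000 nM, within 3000 nM to 50000 nM, a step of a 4.5-fold higher number from compound 1 to compound 4 (0.65 log units; beyond the scatter) that is expected to exceed the scatter.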

Compound 4, half-maximal inhibitory concentration: 32600 nM
Estimate against measurement, compound 4: 2.7-fold (0.43 log units) below, and the stated range covers the measured number.
By their numbers in this assay, from the lowest: compound 1; then compound 4; then compounds 3 and 2 (each within the scatter of the next).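

In this assay, within the data shown here, putting vinyl in place of 4-(trifluoromethyl)phenyl on a saturated chain carbon bound to a sulfur gives the first measured step at this position, a 12-fold higher number from compound 1 to compound 4 (1.09 log units; beyond the scatter), and it is a large one. The position is therefore far from indifferent, and the sulfur with its saturated chain carbon does not by itself hold the number down: compound 4 keeps both and still loses most of the advantage of compound 1, so the outer part of the arm carries much of the effect on this read-out. No measurement at hand explains why the number moves in this way.

From the compounds shown here alone, the aromatic ring and the trifluoromethyl leave together in this single change, so their separate shares remain unknown, and a plain benzyl or a cyclohexylmethyl on the sulfur would be needed to tell them apart. Going by these compounds, whether the sulfur itself matters also stays open, and an oxygen or an amine nitrogen in its place, carrying the same 4-(trifluoromethyl)benzyl, would address that question.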